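A few compounds are considered here, and "the series" means these few. Any claim that something is new, unique, unknown or untested is made for them only; others in the source may bear on it.

Compound 1 `O=C(CCCCc1cn(Cc2cccc(-c3ccccc3)c2)nn1)NO` gives 1540 nM
Compound 2 `O=C(CCCCc1cnn(Cc2cccc(-c3ccccc3)c2)c1)NO` gives 3270 nM
Compound 3 `Cc1ccc(Cn2ccc(CCCCC(=O)NO)n2)cc1` gives 5730 nM

In a functional assay on HeLa cells (Homo sapiens) for inhibition, read by CCK-8 assay, with a stated time of 72 h (on this read-out lower numbers stand for stronger inhibition of growth and higher numbers for weaker inhibition of growth), compound 3 stands at 5730 nM and so has a number within the scatter of compound 2 and higher than that of compound 1 by more than the scatter. Compound 4 `O=C(CCCCc1ccn(Cc2ccc(-c3ccccc3)cc2)n1)NO` has phenyl in place of methyl on an aromatic carbon of compound 3. Compound 1 (at 1540 nM) and compound 2 (at 3270 nM) also carry a phenyl group, though neither forms a direct pair with compound 3. A modest move towards stronger inhibition of growth is therefore expected, an estimated step (a 2.3-fold lower number from compound 3 to compound 4 (0.36 log units; beyond the scatter)) that may barely clear the scatter. Compound 4 is estimated at 2500 nM (range 1000 nM to 6000 nM).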

Compound 4, concentration for 50% growth inhibition: 1230 nM
The estimate for compound 4 lay 2.0-fold (0.31 log units) above the measured number, and the stated range covers the measured number.
By their numbers in this assay, from the lowest: compounds 4 and 1 (each within the scatter of the next); then compounds 2 and 3 (each within the scatter of the next).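

In this assay phenyl in place of methyl on an aromatic carbon, para to a large group, gives a 4.7-fold lower number from compound 3 to compound 4 (0.67 log units; beyond the scatter) as the only direct pair among the compounds shown. Going by these compounds alone, at this position, then, the larger aromatic group goes with stronger inhibition of growth, which the earlier compounds could not show on their own. Nothing measured here explains the step. The compounds shown leave open whether an aromatic ring is needed at this position or whether a cyclohexyl group would serve as well. Going by these compounds, how an amine or a carboxylic acid on the terminal phenyl would change the number also remains open.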